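A few compounds are considered here, and "the series" means these few. Any claim that something is new, unique, unknown or untested is made for them only; others in the source may bear on it.

Working notes on the series.

Compound 2 `CCC1CCCN(C(=O)CN2CN(c3ccccc3)C3(CCN(C(=O)c4ccc(C(C)(C)C)cc4)CC3)C2=O)C1` gives 3900 nM in an assay on HEK293 cells for displacement of a labelled ligand from NPC1-like intracellular cholesterol transporter 1 (Homo sapiens); on this read-out lower numbers stand for stronger inhibition and higher numbers for weaker inhibition. Among the three measured compounds it holds the second highest number. Its nearest neighbour is compound 3 `CC(C)(C)OC(=O)NC1CCCN(C(=O)CN2CN(c3ccccc3)C3(CCN(C(=O)c4ccc(C(C)(C)C)cc4)CC3)C2=O)C1`, which gives 4200 nM; the step of a 1.1-fold higher number from compound 2 to compound 3 (0.03 log units; within the scatter) lies within the scatter. The remaining measured compound, compound 1 `O=C(CN1CN(c2ccccc2)C2(CCN(C(=O)c3ccc(C4CCCCC4)cc3)CC2)C1=O)NCCO`, gives 2000 nM, and its value against that of compound 2 also stays within the scatter.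

The next compound is compound 4 `CC(C)(C)c1ccc(C(=O)N2CCC3(CC2)C(=O)N(CC(=O)NCCCCN)CN3c2ccccc2)cc1`. It differs from compound 2 in one place: (4-aminobutyl)amino in place of 3-ethylpiperidin-1-yl on a carbonyl carbon

Within the data shown here, only one measured step bears on this change, the step of a 1.1-fold higher number from compound 2 to compound 3 (0.03 log units; within the scatter), which exchanges one group for another at the same end of the molecule without moving beyond the scatter. Compound 1, which carries a different amide at that end as well as a different group elsewhere, also sits within the scatter of compound 2. The region therefore looks tolerant of such exchanges, so no step beyond the scatter is expected for compound 4 in this assay, in either direction; the expected step is a 1.3-fold lower number from compound 2 to compound 4 (0.11 log units; within the scatter).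

Compound 4 is therefore expected to give about 3000 nM, within a range of 1200 nM to 8000 nM.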

Compound 4, half-maximal inhibitory concentration: 14500 nM
Beside the measured number, compound 4's estimate is 4.8-fold (0.68 log units) below it; the whole stated range lies below it.
By their numbers in this assay, from the lowest: compounds 1, 2 and 3 (each within the scatter of the next, the first and the last beyond it); then compound 4.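

In this assay the group on this carbonyl carbon is not always interchangeable: the exchange for (4-aminobutyl)amino gives a 3.7-fold higher number from compound 2 to compound 4 (0.57 log units; beyond the scatter) and thus differs from the earlier exchange, which gave a 1.1-fold higher number from compound 2 to compound 3 (0.03 log units; within the scatter) and stayed inside the scatter. Among these compounds, this is the first step from compound 2 at this place to pass the scatter, and its direction is towards weaker inhibition, although its size is only modest. Compound 4 also replaces the ring of 3-ethylpiperidin-1-yl with an open chain and adds hydrogen-bond donors, while nothing shown gives a cause for the step.

Among the compounds shown here, the single step cannot separate the loss of the ring from the arrival of the chain and its terminal amine, since all of these change together between compound 2 and compound 4. Butylamino would speak to the chain without its amine and 3-aminopiperidin-1-yl to the amine with the ring kept, so the compounds shown leave open which of these features goes with the higher number.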